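Working notes: from compound 2 to compound 3

A few compounds are considered here, and "the series" means these few. Any claim that something is new, unique, unknown or untested is made for them only; others in the source may bear on it.

Values measured so far in a functional assay on A549 cells (Homo sapiens) for cytotoxicity (on this read-out lower numbers stand for an effect already at smaller amounts and higher numbers for an effect only at larger amounts of compound), are as follows:
- compound 1 `CCc1ccc(/C=C/C(O)=C2/C(=O)C(C)=C(OC)C(C)(C)C2=O)cc1` gives 6.1 ug/mL in this assay
- compound 2 `COC1=C(C)C(=O)/C(=C(O)/C=C/c2c(C)cccc2C)C(=O)C1(C)C` gives 8.3 ug/mL in this assay

Among the compounds with values here, compound 2 cannot be separated from compound 1 on these numbers, the only other measured compound. Within the data shown here, the sole measured step is a 1.4-fold higher number from compound 1 to compound 2 (0.13 log units; within the scatter) and it exchanged a group at the same place, 2,6-dimethylphenyl in place of 4-ethylphenyl. Compound 3 `COC1=C(C)C(=O)/C(=C(O)/C=C/c2cc(C)cc(C)c2)C(=O)C1(C)C` arises from compound 2 through one exchange, (3,5-dimethylphenyl in place of 2,6-dimethylphenyl on a double-bonded chain carbon bound to a double-bonded chain carbon), on a double-bonded chain carbon bound to a double-bonded chain carbon. Among the measured compounds shown here, no measured compound carries 3,5-dimethylphenyl, so this single step is the only guide. The step expected in this assay is a 1.3-fold lower number from compound 2 to compound 3 (0.11 log units; within the scatter), which means no change beyond the scatter is expected. The estimated value for compound 3 is 6.5 ug/mL, with an expected range from 3 ug/mL to 14 ug/mL in this series.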

Compound 3, concentration for half-maximal effect: 4.3 ug/mL
Compound 3: the middle estimate sits 1.5-fold (0.18 log units) above what was measured, and the stated range covers the measured number.
By their numbers in this assay, from the lowest: compounds 3, 1 and 2 (each within the scatter of the next).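

In this assay, the exchange of 2,6-dimethylphenyl for 3,5-dimethylphenyl, which keeps the same atoms and only rearranges them, is a 1.9-fold lower number from compound 2 to compound 3 (0.29 log units; within the scatter), and the exchange of 4-ethylphenyl for 3,5-dimethylphenyl is a 1.4-fold lower number from compound 1 to compound 3 (0.15 log units; within the scatter). Within the data shown here, this position on the double-bonded chain carbon has now carried three different carbon-only aryl groups, and no step among them leaves the scatter, so moving the two methyl groups around the ring adds no separation that the earlier pair lacked. Nothing at hand bears on why these values stay so close.

As far as these compounds go, it remains open whether a phenyl ring carrying an amine or a carboxylic acid would shift the number beyond the scatter at this position. The same holds for a longer alkyl chain in place of the aryl group.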